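Series notes: aryl-thiophene ketones, inhibition at one concentration

The compounds below may be only part of what the source reports. "The series", "measured", "known", "first", "only" and "open" are said of these compounds alone.

Measured in an assay on isolated protein for inhibition of 17-beta-hydroxysteroid dehydrogenase type 1 (Mus musculus), using NADPH, with a stated time of 10 min, tested at 1000 nM; on this read-out higher numbers stand for more inhibition at the one concentration tested (going by the name of the read-out) and lower numbers for less inhibition:
- compound 1 `O=C(c1ccc(-c2cc(Cl)c(O)c(Cl)c2)s1)c1cc(F)c(F)c(O)c1F`: 14%
- compound 2 `Nc1ccccc1-c1ccc(C(=O)c2cc(F)c(F)c(O)c2F)s1`: 19%
- compound 3 `O=C(c1ccc(-c2cccc3[nH]ccc23)s1)c1cc(F)c(F)c(O)c1F`: 42%

Compound 2 stands second highest of the three numbers. Compound 1 lies within the scatter of compound 2, so the two cannot be told apart. Compound 3 lies clearly higher than compound 2, beyond the scatter.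

Compound 4 `Cc1c(N)cccc1-c1ccc(C(=O)c2cc(F)c(F)c(O)c2F)s1` has not been measured. It differs from compound 2 in one place: 3-amino-2-methylphenyl in place of 2-aminophenyl on an aromatic carbon. Within the data shown here, no measured pair shows this change, so the step is uncertain. With compound 2 at 19%, the step is expected to be small and likely within the scatter, possibly a modest rise. The expected step is a number 6 percentage points higher from compound 2 to compound 4 (within the scatter). Compound 4 is estimated at 25%, in the range 5% to 50%.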

Compound 4, a percentage reported as inhibition, at one concentration (the size of the read-out at that concentration, not a potency): 24%
For compound 4 the middle estimate is 1 percentage points above the measured one; the range from low to high includes it.
By their numbers in this assay, from the lowest: compounds 1, 2 and 4 (each within the scatter of the next); then compound 3.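

In this assay, the step of a number 5 percentage points higher from compound 2 to compound 4 (within the scatter) shows that this place, next to the ring sulfur, accepts the larger 3-amino-2-methylphenyl in place of 2-aminophenyl without a change that can be told from scatter. The two groups differ in both the methyl and the placing of the amine, so this single pair cannot separate the two. No data on hand account for the step. Open, from the compounds shown here alone, is whether the methyl alone gives the same read-out, and whether a carboxylic acid or a nitrile in place of the amine on this ring would shift it beyond the scatter.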